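Same Ring Swap, Second Time, on Heart Cells

This account rests on a few compounds, and the source may have more. Where it says the series, first, only, none or still open, it means among the compounds named here.

Compound 1, `NC(=S)c1ccc(OC(=O)c2cccnc2)cc1`, was tested in an ADME assay on H9c2 cells (Rattus norvegicus) for cytotoxicity, read by MTT assay, with a stated time of 48 h (on this read-out higher numbers stand for weaker inhibition and lower numbers for stronger inhibition), and gave 754000 nM. Compound 2, `O=C(Oc1ccc(-c2cc(=S)ss2)cc1)c1cccnc1`, differs from compound 1 in one place: a group of 6 heavy atoms (3 carbon, 3 sulfur; one five-membered aromatic ring with 2 hetero atoms) in place of a group of 3 heavy atoms (1 carbon, 1 nitrogen, 1 sulfur; no ring), on an aromatic carbon. In this assay compound 2 gave 627000 nM, and the measured step is a 1.2-fold lower number from compound 1 to compound 2 (0.08 log units; within the scatter). Compound 3, `CC(C)(Oc1ccc(Cl)cc1)C(=O)Oc1ccc(C(N)=S)cc1`, carries a different core; how the core of compound 3 differs from the core of compound 1 is not broken down here. In this assay compound 3 gave 797000 nM, and its number, the number of compound 1 and the number of compound 2 all lie within the usual scatter of one another, so no order among them is claimed.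

Compound 4, `CC(C)(Oc1ccc(Cl)cc1)C(=O)Oc1ccc(-c2cc(=S)ss2)cc1`, has not yet been tested in this assay. It stands to compound 3 as compound 2 stands to compound 1: a group of 6 heavy atoms (3 carbon, 3 sulfur; one five-membered aromatic ring with 2 hetero atoms) in place of a group of 3 heavy atoms (1 carbon, 1 nitrogen, 1 sulfur; no ring), on an aromatic carbon. The surroundings of the place are not described in quite the same words for the two pairs, since in compound 3 the changed group sits para to a large group, so this is the same kind of change rather than the same change. The expected step is a 1.2-fold lower number from compound 3 to compound 4 (0.08 log units; within the scatter), and this expectation rests on the measured step of a 1.2-fold lower number from compound 1 to compound 2 (0.08 log units; within the scatter), which stayed within the scatter. The estimate for compound 4 in this assay is therefore 660000 nM, expected to fall between 350000 nM and 1200000 nM.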

Compound 4, half-maximal inhibitory concentration: 675000 nM
Estimate against measurement, compound 4: 1.0-fold (0.01 log units) below; measured number inside the range.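

In this assay, putting the five-membered sulfur-containing ring in place of the smaller open group gives a 1.2-fold lower number from compound 3 to compound 4 (0.07 log units; within the scatter), so on this second core the change again leaves the number within the scatter. Set side by side, the two steps agree: the same change on two cores in this assay, a 1.2-fold lower number (0.08 log units; within the scatter) from compound 1 to compound 2 and a 1.2-fold lower number (0.07 log units; within the scatter) from compound 3 to compound 4, 1.0-fold (0.01 log units) apart, within the scatter of two such steps This shows that, on these two cores and in this one cell assay, the change carried across without a measurable shift, but the agreement is between two steps that cannot be told from no step at all, so it does not show that the ring lowers the number on either core, nor that a real effect was repeated, and it says nothing about other cores or other assays.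

The compounds shown leave open whether any group at this place on the aromatic carbon, such as an amine, a carboxylic acid or a longer chain, would move the number beyond the scatter, since only these two groups are compared there. They also leave open whether the same quiet result would hold on a third core, for example one with an amide in place of the ester link.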